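Moving the Chloro Around the Benzyl Ring

The compounds below may be only part of what the source reports. "The series", "measured", "known", "first", "only" and "open" are said of these compounds alone.

In an ADME assay on microsomes from liver (Homo sapiens) for metabolic stability, read by LC-MS, using NADPH, tested at 5 uM (on this read-out higher numbers stand for a longer-lived compound and lower numbers for a shorter-lived compound), compound 2 `Cc1cc(-c2ccccc2)n(/C(N)=N/S(=O)(=O)c2cc(C)c(Cl)cc2SCc2cccc(Cl)c2)n1` gives 0.205 h, and compound 1 `Cc1cc(-c2ccccc2)n(/C(N)=N/S(=O)(=O)c2cc(C)c(Cl)cc2SCc2cccc(C(F)(F)F)c2)n1` gives 0.169 h, within the scatter of it. Going by the values given here, the only measured step, a 1.2-fold higher number from compound 1 to compound 2 (0.08 log units; within the scatter), exchanges one group for another and stayed within the scatter. Compound 3 `Cc1cc(-c2ccccc2)n(/C(N)=N/S(=O)(=O)c2cc(C)c(Cl)cc2SCc2ccccc2Cl)n1` differs from compound 2 by 2-chlorophenyl in place of 3-chlorophenyl on a saturated chain carbon bound to a sulfur. Among the compounds with values here, no measured step shifts a chloro from one ring carbon to another, so that earlier step offers only loose guidance, and no change beyond the scatter is expected. For compound 3 the expected step is a 1.0-fold lower number from compound 2 to compound 3 (0.01 log units; within the scatter). Compound 3 is therefore estimated to give 0.2 h, between 0.1 h and 0.4 h.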

Compound 3, half-life: 0.163 h
Compound 3: middle estimate off by 1.2-fold (0.09 log units), on the high side; measured number inside the range.
By their numbers in this assay, from the lowest: compounds 3, 1 and 2 (each within the scatter of the next).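

In this assay, shifting the chloro from 3-chlorophenyl to 2-chlorophenyl on the saturated chain carbon bound to a sulfur gives a 1.3-fold lower number from compound 2 to compound 3 (0.10 log units; within the scatter), the first measured move of a chloro between ring carbons, and the half-life stays within the scatter. Replacing 3-(trifluoromethyl)phenyl with 2-chlorophenyl at the same place gives a 1.0-fold lower number from compound 1 to compound 3 (0.02 log units; within the scatter), also within the scatter. Nothing available accounts for how close these numbers lie. Still open, from the compounds shown here alone, is whether an amine or a carboxylic acid on this ring would stay within the scatter too.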